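This account rests on a few compounds, and the source may have more. Where it says the series, first, only, none or still open, it means among the compounds named here.

The measured compounds:
Compound 1, `C/C(=N\NC(=O)c1cccc(S(=O)(=O)N2CCOCC2)c1)c1ccc(F)cc1`: in a functional assay on PC-3 cells (Homo sapiens) for antiproliferative activity, read by MTT assay, with a stated time of 72 h (on this read-out lower numbers stand for stronger inhibition and higher numbers for weaker inhibition), compound 1 gives 81300 nM.
Compound 2, `C/C(=N\NC(=O)c1cccc(S(=O)(=O)N2CCOCC2)c1)c1ccccc1O`: in this assay compound 2 gives 2810 nM.
Compound 3, `C/C(=N\NC(=O)c1cccc(S(=O)(=O)N2CCOCC2)c1)c1cc(O)ccc1O`: in this assay compound 3 gives only a limit of the assay, > 100000 nM.

Compound 3 thus stands at the top of the numbers shown, resting on the limit of > 100000 nM in this assay, at which 1 of the 3 values shown sits, rather than on a measured value. Compound 4, `C/C(=N\NC(=O)c1cccc(S(=O)(=O)N2CCOCC2)c1)c1cccc(N)c1O`, differs from compound 3 in one place: 3-amino-2-hydroxyphenyl in place of 2,5-dihydroxyphenyl on a carbon with a double bond to nitrogen. Among the measured compounds shown here, two measured steps bear on this change. The first is a 29-fold lower number from compound 1 to compound 2 (1.46 log units; beyond the scatter), which shows what the 2-hydroxyphenyl group alone brings. The second is an at least 35-fold higher number from compound 2 to compound 3 (1.55 log units; beyond the scatter), which shows that the second hydroxy of compound 3 removed that gain. For the measured compounds named here, compound 4 keeps the 2-hydroxyphenyl pattern of compound 2 and drops the second hydroxy, while an amino enters within the 3-amino-2-hydroxyphenyl group, for which no measured step exists. A fall in the number toward compound 2 is therefore expected, though the amino leaves the size open. The step expected here is an at least 6.6-fold lower number from compound 3 to compound 4 (0.82 log units; beyond the scatter). Compound 4 is estimated at 15000 nM, with a range from 2500 nM to 100000 nM.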

Compound 4, half-maximal inhibitory concentration: 2330 nM
Beside the measured number, compound 4's estimate is 6.4-fold (0.81 log units) above it; the measured number lies below the stated range.
By their numbers in this assay, from the lowest: compounds 4 and 2 (each within the scatter of the next); then compound 1. At a limit, above all of these: compound 3.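

In this assay, amino in place of hydrogen on an aromatic carbon gives a 1.2-fold lower number from compound 2 to compound 4 (0.08 log units; within the scatter), so this added group, unlike the second hydroxy of compound 3, keeps what the 2-hydroxyphenyl group brought. That gain stands against the 4-fluorophenyl group, with a 35-fold lower number from compound 1 to compound 4 (1.54 log units; beyond the scatter), and the choice of the added group on the same ring carries a large step, with an at least 42-fold lower number from compound 3 to compound 4 (1.63 log units; beyond the scatter). Compound 3 itself rests on a limit of the assay, so that last step is only a floor: the limit of > 100000 nM in this assay, at which 1 of the 4 values shown sits.

The compounds shown leave open whether a methoxy, a chlorine or a dimethylamino in place of the amino would also keep the gain. They also leave open why the amino and the second hydroxy part ways, as nothing here tells the cause.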